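Swapping the Ketone Aryl Group in a Thiophene Series

The source may report more compounds than this note shows. Statements on the series, on what has been measured and on what is new or still open speak of the compounds shown alone.

Of the compounds shown here, three have been measured in an assay on CHO cells for displacement of a labelled ligand from adenosine receptor A3 (Homo sapiens), read by scintillation counting, with a stated time of 120 min, tested at 10 uM (on this read-out higher numbers stand for more inhibition at the one concentration tested (going by the name of the read-out) and lower numbers for less inhibition), and all three gave very little displacement. Compound 1 `Nc1scc(CN2CCN(c3cccc(Cl)c3Cl)CC2)c1C(=O)c1ccc(Cl)cc1` gives 0%. Compound 2 `Nc1scc(CN2CCN(c3ccc(Cl)c(C(F)(F)F)c3)CC2)c1C(=O)c1ccc(Cl)cc1` gives 3%; the move from compound 1 to compound 2 was a number 3 percentage points higher from compound 1 to compound 2 (within the scatter). Compound 3 `Nc1scc(CN2CCN(c3c(F)cccc3F)CC2)c1C(=O)c1cccc(C(F)(F)F)c1` gives 0%, level with compound 1 at the digits shown, the two together the lowest of the three numbers, and within the scatter of compound 2.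

Compound 4 `Nc1scc(CN2CCN(c3c(F)cccc3F)CC2)c1C(=O)c1ccc(Cl)cc1` differs from compound 3 by 4-chlorophenyl in place of 3-(trifluoromethyl)phenyl on a carbonyl carbon. For the measured compounds named here, the only measured step, from compound 1 to compound 2, concerns the group on the amine nitrogen in the ring, not the group on the carbonyl carbon, so it does not bear directly on this change. What the data do show is that compound 1 and compound 2 both already carry the 4-chlorophenyl on the carbonyl carbon: compound 1 gave 0% and compound 2 gave 3%, both within the scatter of compound 3. On that basis compound 4 is expected to stay at the same low level, with a number 2 percentage points higher from compound 3 to compound 4 (within the scatter) and no step beyond the scatter. The estimate for compound 4 in this assay is 2%, in a range from -6% to 12%.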

Compound 4, a percentage reported as inhibition, at one concentration (the size of the read-out at that concentration, not a potency): 4%
The estimate for compound 4 lay 2 percentage points below the measured number; the measured number falls inside the stated range.
By their numbers in this assay, from the lowest: compounds 1, 3, 2 and 4 (each within the scatter of the next).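

Placing 4-chlorophenyl in place of 3-(trifluoromethyl)phenyl on the carbonyl carbon gives a number 4 percentage points higher from compound 3 to compound 4 (within the scatter) in this assay and is the first direct reading at this position, where the two aryl groups cannot be told apart. With 4-chlorophenyl held on the carbonyl carbon, 2,6-difluorophenyl on the amine nitrogen in the ring gives a number 1 percentage points higher from compound 2 to compound 4 (within the scatter) when it replaces 4-chloro-3-(trifluoromethyl)phenyl and a number 4 percentage points higher from compound 1 to compound 4 (within the scatter) when it replaces 2,3-dichlorophenyl, so none of these three groups on the nitrogen stands apart from the others either. Nothing here explains why all of these changes leave the numbers indistinguishable.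

Going by these compounds, it stays open whether a carboxylic acid or a short alkyl chain on the carbonyl carbon, in place of the aryl ring, would move the number beyond the scatter. The same question holds for the amine nitrogen in the ring, where a phenyl group carrying an amine or a carboxylic acid would test something other than the halogen-bearing rings shown so far.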